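A few compounds are considered here, and "the series" means these few. Any claim that something is new, unique, unknown or untested is made for them only; others in the source may bear on it.

Compound 3 `Cc1ccc(O)c(/C=N/NC(=S)N/N=C2\C(=O)Nc3ccc(C)cc32)c1` stands at the limit of this assay (the limit of > 50000 nM in this assay, at which 2 of the 3 values shown sit). In a functional assay on COS-7 cells (Chlorocebus aethiops) for inhibition, read by MTT assay (a higher number here means a weaker inhibitor, a lower number a stronger inhibitor), compound 3 gives only the limit > 50000 nM, not a number. Compound 1 `O=C1Nc2ccc(Br)cc2/C1=N/NC(=S)N/N=C/c1ccccc1Br` likewise reports only the limit > 50000 nM in this assay. Going by the values given here, compound 2 `COc1ccc(/C=N/NC(=S)N/N=C2\C(=O)Nc3ccc(C)cc32)cc1O` is the sole member with a number, 3190 nM in this assay, and the one measured step is an at least 15-fold higher number from compound 2 to compound 3 (1.19 log units; beyond the scatter). Compound 4 `Cc1ccc2c(c1)/C(=N/NC(=S)N/N=C/c1ccccc1Br)C(=O)N2` differs from compound 3 by 2-bromophenyl in place of 2-hydroxy-5-methylphenyl on a carbon with a double bond to nitrogen. That measured step does not touch the 2-bromophenyl group. Compound 1, carrying the same 2-bromophenyl on its core, sits at the limit in this assay. With that in view, compound 4 is expected to stay at the limit, a step of a number no higher from compound 3 to compound 4 (the limit leaves the size open). Compound 4 is therefore estimated at 50000 nM, within a range from 10000 nM to 200000 nM.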

Compound 4, half-maximal inhibitory concentration: > 50000 nM
Compound 4: no number, only a limit; the forecaster's own chance of this, stated with the estimate: 70%; the middle value sits exactly at the limit.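

On the shared core in this assay, 2-bromophenyl in place of 3-hydroxy-4-methoxyphenyl gives an at least 15-fold higher number from compound 2 to compound 4 (1.19 log units; beyond the scatter), so a second replacement, this one without a hydroxy group, also loses the measurable value. Of the groups shown on this core, only 3-hydroxy-4-methoxyphenyl gives a number, and compound 4 reports only a limit: the limit of > 50000 nM in this assay, at which 3 of the 4 values shown sit. The steps from compound 3 to compound 4 and from compound 1 to compound 4 have limits at both ends and cannot be read.

Going by these compounds, it remains open whether the hydroxy or the methoxy group alone would give a number on this phenyl ring. Also open, on these data alone, is whether an amine or a carboxylic acid there would do so.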